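Chloro to hydrogen on the pendant aryl of two cores

A few compounds are considered here, and "the series" means these few. Any claim that something is new, unique, unknown or untested is made for them only; others in the source may bear on it.

Measured compounds:
compound 1, `Nc1cccc(-c2cn3nc(Cc4ccccc4)sc3n2)c1`, gives 7400 nM in a functional assay on L1210 cells (Mus musculus) for inhibition, read by cell counting, with a stated time of 2 days; a lower number here means a stronger inhibitor, a higher number a weaker inhibitor
compound 2, `Nc1cccc(-c2cn3nc(Cc4ccc(Cl)cc4)sc3n2)c1`, gives 16000 nM in this assay
compound 3, `Nc1cccc(-c2cn3c(-c4ccc(Cl)cc4)csc3n2)c1`, gives 22000 nM in this assay

Compounds 1 and 2 share one core; compound 3 carries another, and the difference between the two cores is not broken down here. Within the first pair the change is hydrogen in place of chloro on an aromatic carbon, and it gave a 2.2-fold lower number from compound 2 to compound 1 (0.33 log units; beyond the scatter). Compound 3 and compound 2 lie within the scatter of each other, while compound 1 gives a lower number than compound 3 by a gap beyond the scatter.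

Compound 4, `Nc1cccc(-c2cn3c(-c4ccccc4)csc3n2)c1`, is not yet measured in this assay. For the measured compounds named here, it differs from compound 3 by hydrogen in place of chloro on an aromatic carbon, the same change, on the same place, as the one from compound 2 to compound 1. Because the same change gave a 2.2-fold lower number from compound 2 to compound 1 (0.33 log units; beyond the scatter) on the other core, compound 4 is expected to show a step of a 2.2-fold lower number from compound 3 to compound 4 (0.34 log units; beyond the scatter) and to land near 10000 nM, with a range of 5000 nM to 25000 nM. This rests on a single prior step and on a core that is not the same, so the expectation is held loosely.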

Compound 4, half-maximal inhibitory concentration: 85000 nM
Compound 4: the middle estimate sits 8.5-fold (0.93 log units) below what was measured, and the stated range ends below it.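

In this assay, the change from 4-chlorophenyl to phenyl gave a 3.9-fold higher number from compound 3 to compound 4 (0.59 log units; beyond the scatter), so on this core the chloro compound is the stronger inhibitor, the reverse of what was seen on the core of compound 1. The change therefore does not carry over from one core to the other in this pair of cores, and a step read on one of them gives no safe guide to its direction on the other: the same change on two cores in this assay, a 2.2-fold lower number (0.33 log units; beyond the scatter) from compound 2 to compound 1 and a 3.9-fold higher number (0.59 log units; beyond the scatter) from compound 3 to compound 4, 8.4-fold (0.92 log units) apart, beyond the scatter of two such steps This rests on a single pair on each core, and it does not show which feature of the two cores goes with the reversal or whether the reversal extends beyond these four compounds.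

Still open, on these data alone, is whether the reversal belongs to chloro alone or also appears when a fluoro, methoxy or trifluoromethyl group stands at the same place on both cores. Also open, as far as these compounds go, is how each core responds when a hydroxyl group or an acetamide replaces the amine on the aniline ring.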